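Chloro on the phenyl ring of compound 2

A few compounds are considered here, and "the series" means these few. Any claim that something is new, unique, unknown or untested is made for them only; others in the source may bear on it.

Among the compounds with values here, in a functional assay on PC-3M cells (Homo sapiens) for inhibition, read by sulforhodamine B assay (on this read-out higher numbers stand for weaker inhibition and lower numbers for stronger inhibition), compound 1 (`Cc1nc2c(N3CCC(N)CC3)ncnc2[nH]1`) has "not determined" (no result reported) as its entry, so compound 2 (`NC(c1ccccc1)C1CCN(c2ncnc3[nH]ccc23)CC1`) at 38000 nM holds the only number. Compound 3 (`NC(c1ccc(Cl)cc1)C1CCN(c2ncnc3[nH]ccc23)CC1`) carries chloro in place of hydrogen on an aromatic carbon. Within the data shown here, no measured step is available to size this change. A small shift in this assay toward stronger inhibition is expected, possibly none beyond the usual scatter (a 1.5-fold lower number from compound 2 to compound 3 (0.18 log units; within the scatter) as the estimated step). In this assay compound 3 is estimated at 25000 nM (expected range 10000 nM to 55000 nM).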

Compound 3, half-maximal inhibitory concentration: 7400 nM
Estimate against measurement, compound 3: 3.4-fold (0.53 log units) above, outside the stated range (below it).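

In this assay, the phenyl ring of compound 2 responds to substitution: chloro on an aromatic carbon, para to a large group, gives a 5.1-fold lower number from compound 2 to compound 3 (0.71 log units; beyond the scatter). Within the data shown here, this is the first measured step, and a single chlorine atom moves the number toward stronger inhibition by more than the scatter. Nothing available here accounts for the size of this step.

From the compounds shown here alone, whether the gain is specific to chloro or would also appear with a methoxy group or an amine on the same carbon remains open. The effect of chloro on other carbons of the ring is also unknown.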